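The source may hold more compounds than are shown below. What is called first, only, known or untested is meant among the compounds shown, and "the series" means these compounds.

Measured compounds:

compound 1, `O=C(Nc1ccc(Cl)cc1CN1C(=O)c2ccccc2C1=O)c1cccnc1`, gives < 1000 nM
compound 2, `O=C(Nc1ccc(Cl)cc1CN1C(=O)c2ccccc2C1=O)c1ccccc1C(F)(F)F`, gives < 1000 nM
compound 3, `O=C(Nc1ccc(Cl)cc1CN1C(=O)c2ccccc2C1=O)C1CCCCC1`, gives < 1000 nM

In an assay on CHO cells for positive allosteric modulation of metabotropic glutamate receptor 5 (Rattus norvegicus), read by FLIPR (a lower number here means that less compound is needed, a higher number that more compound is needed for the effect), compound 1 gives < 1000 nM, and this is a limit of the assay rather than a measured number. Compound 2 likewise stands at a limit, < 1000 nM. Compound 3 also stands at a limit, < 1000 nM. So compound 1 cannot be placed above or below its two neighbours: all three share the same limit, and nothing separates them.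

The three steps among these compounds are therefore a step that the two limits leave unreadable from compound 1 to compound 2, a step that the two limits leave unreadable from compound 1 to compound 3 and a step that the two limits leave unreadable from compound 2 to compound 3. They stay unreadable because the limit of < 1000 nM in this assay, at which 3 of the 3 values shown sit, holds every value shown, so no size and no direction can be taken from them.

Compound 4, `O=C(Nc1ccc(Cl)cc1CN1C(=O)c2ccccc2C1=O)c1ncccc1O`, differs from compound 1 in one place: 3-hydroxypyridin-2-yl in place of pyridin-3-yl on a carbonyl carbon. Going by the values given here, no measured step gives a size for a change of this kind, so the step from compound 1 to compound 4 in this assay is expected to be a step that the limit leaves unreadable from compound 1 to compound 4, nothing beyond the usual scatter. Compound 4 is accordingly estimated at 500 nM, ranging from 100 nM to 2500 nM, with a real chance that the assay again reports only a limit.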

Compound 4, half-maximal effective concentration: < 1000 nM
Compound 4 gave a limit, no number; the forecaster's own chance of this, stated with the estimate: 55%; the middle value lies beyond the limit too.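

In this assay compound 4 gives < 1000 nM, which is a limit of the assay and not a number. Its steps to compound 1, compound 2 and compound 3 cannot be read, because all four compounds share one limit: the limit of < 1000 nM in this assay, at which 4 of the 4 values shown sit. The compounds shown leave open how far apart their true values lie, and whether changing the group on the carbonyl carbon makes any difference at all.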